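From Allyl to Phenyl on the Ring Nitrogen

The source may report more compounds than this note shows. Statements on the series, on what has been measured and on what is new or still open speak of the compounds shown alone.

Compound 2 `C=CCn1c(SC/C(=N/O)c2ccccc2)nnc1-c1cc(OC)c(OC)c(OC)c1` was measured in a functional assay on the whole organism (strain albino) for inhibition, with Rattus norvegicus as the target, read by paw edema, with a stated time of 4 h, at a dose of 0.28 mmol/kg by the oral route (a higher number here means more inhibition at the dose given (going by the name of the read-out), a lower number less inhibition), where compound 2 gives 73%. Among the two numbers known, compound 2 sits at one end; the other belongs to compound 1 `CCn1c(SC/C(=N/O)c2ccccc2)nnc1-c1cc(OC)c(OC)c(OC)c1`, which in this assay gives 79%, within the scatter of compound 2. Compound 3 `COc1cc(-c2nnc(SC/C(=N/O)c3ccccc3)n2-c2ccccc2)cc(OC)c1OC` differs from compound 2 by phenyl in place of allyl on an aromatic nitrogen. Among the measured compounds shown here, the only measured step, a number 6 percentage points lower from compound 1 to compound 2 (within the scatter), concerns a small change on the saturated chain, so no measured step speaks directly to an aromatic group entering here. Compound 3 is therefore expected to give 70%, between 52% and 85%, with the expected a number 3 percentage points lower from compound 2 to compound 3 (within the scatter) lying within the scatter.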

Compound 3, a percentage reported as inhibition, in the whole organism at one dose (the size of the read-out at that dose, not a potency): 76%
Estimate against measurement, compound 3: 6 percentage points below, and the stated range covers the measured number.
By their numbers in this assay, from the lowest: compounds 2, 3 and 1 (each within the scatter of the next).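

On the aromatic nitrogen, a ring can stand where only open chains had stood, and the inhibition in this assay stays within the scatter of both chain compounds: phenyl in place of allyl gives (a number 3 percentage points higher from compound 2 to compound 3 (within the scatter)), and phenyl in place of ethyl gives (a number 3 percentage points lower from compound 1 to compound 3 (within the scatter)). Ethyl, allyl and phenyl therefore cannot be told apart at this position in this read-out. No evidence at hand bears on this result. Still open, as far as these compounds go, is how this nitrogen would respond to a longer chain, a chain ending in an amine or a carboxylic acid, or a phenyl carrying a methoxy group.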